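The source may hold more compounds than are shown below. What is called first, only, known or untested is meant among the compounds shown, and "the series" means these compounds.

Measured in an ADME assay for permeability, using PAMPA, with a stated time of 30 min, at pH 7.4; on this read-out lower numbers stand for lower permeability and higher numbers for higher permeability:
- compound 1, `CC(C)Cc1ccc2c(NCCCNCc3ccco3)ccnc2c1`: 23 10^-6 cm/s
- compound 2, `CCC(CC)c1ccc2c(NCCCNCc3cccc(OC)c3O)ccnc2c1`: 23 10^-6 cm/s
- compound 3, `COc1cccc(CNCCCNc2ccnc3cc(Oc4ccccc4)ccc23)c1O`: 317 10^-6 cm/s

Compound 3 gives the highest number of the three; compound 1 and compound 2 both sit far below it, each by the same margin and beyond the scatter. Within the data shown here, the only single-point step onto compound 3 is a 14-fold higher number from compound 2 to compound 3 (1.14 log units; beyond the scatter), a large one.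

Compound 4, `COc1cccc(CNCCCNc2ccnc3cc(CC(C)C)ccc23)c1O`, has not yet been measured in this assay. Its difference from compound 3 is isobutyl in place of phenoxy on an aromatic carbon. Among the measured compounds shown here, the one measured step that bears on this change is a 14-fold higher number from compound 2 to compound 3 (1.14 log units; beyond the scatter), in which phenoxy entered on an aromatic carbon and the number rose well beyond the scatter; compound 4 runs an exchange of that kind the other way, phenoxy leaving and isobutyl entering. Compound 1 also carries isobutyl, and in this assay compound 1 gives 23 10^-6 cm/s, a number within scatter of compound 2; compound 1 differs from compound 3 in a second place as well, so it serves only as a pointer. Compound 4 is therefore expected to fall back toward the two lower numbers, with an expected step of an 11-fold lower number from compound 3 to compound 4 (1.02 log units; beyond the scatter). The estimate for compound 4 in this assay is 30 10^-6 cm/s, with a range from 12 10^-6 cm/s to 80 10^-6 cm/s.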

Compound 4, apparent permeability: 23 10^-6 cm/s
Compound 4: the middle estimate sits 1.3-fold (0.12 log units) above what was measured; the measured number falls inside the stated range.
By their numbers in this assay, from the lowest: compounds 1, 2 and 4 (each within the scatter of the next); then compound 3.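

With the 2-hydroxy-3-methoxyphenyl side held fixed, isobutyl in place of phenoxy on this aromatic carbon gives a large drop in this assay (a 14-fold lower number from compound 3 to compound 4 (1.14 log units; beyond the scatter)), so the high number of compound 3 is now seen against a second group at this position, not against pentan-3-yl alone. Isobutyl and pentan-3-yl are not separated at this position (no change at the digits printed from compound 2 to compound 4 (within the scatter)), and with isobutyl in place, 2-hydroxy-3-methoxyphenyl in place of furan-2-yl on the saturated chain carbon bound to an amine nitrogen likewise shows no separation (no change at the digits printed from compound 1 to compound 4 (within the scatter)), so among the compounds shown, only the one carrying phenoxy stands apart. No independent measurement is available to account for the phenoxy result.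

On these data alone, whether the high number needs the whole phenoxy group remains open: a phenyl or benzyl group would test the ring without the ether oxygen, and a methoxy group the ether oxygen without the ring. Also open, as far as these compounds go, is whether phenoxy gives a similar number when furan-2-yl replaces 2-hydroxy-3-methoxyphenyl on the chain.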